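The compounds below may be only part of what the source reports. "The series", "measured", "known", "first", "only" and "open" are said of these compounds alone.

The series rests on a shared saturated bicyclic amine core. Compound 1 `C[C@@H]1C[C@@H]1C(=O)N1CC2CNCC2C1` carries a small cyclopropane amide on that core, and in an assay on CHO cells for agonist activity at Neuronal acetylcholine receptor; alpha3/beta4 (Homo sapiens), read by FLIPR and calcium flux (a higher number here means a larger maximal response, a lower number a smaller maximal response), compound 1 gives 180%. Compound 2 `O=C(c1ccco1)[C@H]1C[C@@H]2CNC[C@@H](C2)C1` moves to a larger core and bears a furan-2-yl ketone on a saturated ring carbon; for this assay compound 2 has no single number, as the result is recorded as "not determined" (no result reported). Compound 3 `CC(C)NC(=O)[C@H]1C[C@@H]2CNC[C@@H](C2)C1` keeps the core of compound 2 and changes only the group on the carbonyl carbon: isopropylamino in place of furan-2-yl on a carbonyl carbon. Since compound 2 offers no value, the size of the step in this assay from compound 2 to compound 3 cannot be gauged against a measured neighbour, and nothing in the two remaining measurements points to a particular direction. The only anchor is the amide of compound 1, which in this assay reaches 180%, while compound 3 sits on a different core. On that thin basis the maximal response of compound 3 in this assay is estimated at 100%, with a likely range from 30% to 170%.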

Compound 3, largest response reached (Emax), in percent of the reference or control that the assay uses: 25%
Estimate against measurement, compound 3: 75 percentage points above; measured number below the stated range.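

Going by these compounds alone, compound 2 has no number in this assay and compound 3 gives 25% there, so no step from one to the other can be read. The compounds shown leave open what exchanging furan-2-yl for isopropylamino on the carbonyl carbon does to the maximal response. No supporting data bear on the result for compound 3.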